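The compounds below may be only part of what the source reports. "The series", "measured", "known", "first", "only" and "open" are said of these compounds alone.

Compound 3 `N#Cc1cnc(NCc2cnccc2C(F)(F)F)cc1NCCC1CCOCC1` carries the highest number of the three compounds measured in an assay on isolated protein for inhibition of protein kinase C theta type (Homo sapiens), read by TR-FRET, with a stated time of 2 h; on this read-out higher numbers stand for weaker inhibition and lower numbers for stronger inhibition: in this assay compound 3 gives 1200 nM. Compound 2 `CO[C@H]1CC[C@H](Nc2cc(NCc3cnccc3C(F)(F)F)ncc2C#N)CC1` gives 1100 nM, and the pair lie close together, as a 1.1-fold higher number from compound 2 to compound 3 (0.04 log units; within the scatter) shows. Compound 1 `N#Cc1cnc(NCc2cnccc2C(F)(F)F)cc1NC[C@H]1C[C@@H](O)C1` gives 300 nM, and the step of a 4.0-fold higher number from compound 1 to compound 3 (0.60 log units; beyond the scatter) sets it clearly apart from compound 3, while a 3.7-fold higher number from compound 1 to compound 2 (0.56 log units; beyond the scatter) likewise lies beyond the scatter.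

Compound 4 `CC1(C)[C@@H](C(N)=O)C[C@H]1Nc1cc(NCc2cnccc2C(F)(F)F)ncc1C#N` differs from compound 3 in one place: 3-carbamoyl-2,2-dimethylcyclobutyl in place of 2-(oxan-4-yl)ethyl on a nitrogen on an aromatic ring. Of the measured steps, a 4.0-fold higher number from compound 1 to compound 3 (0.60 log units; beyond the scatter) bears most directly on this change, since compound 1 likewise carries a four-membered carbon ring with one hydrogen-bond donor on the same nitrogen, and a 1.1-fold higher number from compound 2 to compound 3 (0.04 log units; within the scatter) shows that swapping between the two larger saturated oxygen-containing groups changes little. A step toward a lower number is therefore expected for compound 4, of roughly the size seen between compound 3 and compound 1, that is a 3.4-fold lower number from compound 3 to compound 4 (0.54 log units; beyond the scatter). In this assay compound 4 is estimated at 350 nM, with a likely range from 100 nM to 1200 nM.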

Compound 4, half-maximal inhibitory concentration: 1.4 nM
For compound 4 the middle estimate is 250-fold (2.40 log units) above the measured one; measured number below the stated range.
By their numbers in this assay, from the lowest: compound 4; then compound 1; then compounds 2 and 3 (each within the scatter of the next).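

In this assay, for the compounds shown here, the group on the nitrogen on the aromatic ring can shift the number far more than the modest steps among the earlier compounds indicated, as 3-carbamoyl-2,2-dimethylcyclobutyl shows against two larger groups (an 860-fold lower number from compound 3 to compound 4 (2.93 log units; beyond the scatter); a 790-fold lower number from compound 2 to compound 4 (2.90 log units; beyond the scatter)). A four-membered carbon ring alone does not bring this result, since the (3-hydroxycyclobutyl)methyl group also contains one and remains well apart (a 210-fold lower number from compound 1 to compound 4 (2.33 log units; beyond the scatter)). Nothing available here accounts for the size of these steps.

The compounds shown do not separate the contributions of the carbamoyl group, the two methyl groups and the two defined stereocentres. They also leave open how a carboxylic acid or a primary amine in place of the carbamoyl group would read in this assay.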